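Amine substituent change within the series

A few compounds are considered here, and "the series" means these few. Any claim that something is new, unique, unknown or untested is made for them only; others in the source may bear on it.

The three measured compounds share one core; compound 1 `CC(C)=CCc1cc(C(=O)Nc2cc3ccc(OCC4CCCNC4)c(C)c3oc2=O)ccc1O`, compound 2 `CCNCCCOc1ccc2cc(NC(=O)c3ccc(O)c(CC=C(C)C)c3)c(=O)oc2c1C` and compound 3 `CC(C)=CCc1cc(C(=O)Nc2cc3ccc(OCCCNC(C)(C)C)c(C)c3oc2=O)ccc1O` differ only in the side chain on a saturated chain carbon bound to an oxygen on an aromatic ring. In a functional assay on SK-BR-3 cells (Homo sapiens) for antiproliferative activity (a higher number here means a weaker inhibitor, a lower number a stronger inhibitor), compound 1 gives 600 nM, compound 2 gives 720 nM and compound 3 gives 660 nM. Compound 2 has the highest of the three numbers, yet a 1.2-fold higher number from compound 1 to compound 2 (0.08 log units; within the scatter) and a 1.1-fold lower number from compound 2 to compound 3 (0.04 log units; within the scatter) both fall within the scatter, as does a 1.1-fold higher number from compound 1 to compound 3 (0.04 log units; within the scatter). Compound 4 `CC(C)=CCc1cc(C(=O)Nc2cc3ccc(OCCCN[C@@H]4C[C@H]5CC[C@@H]4C5)c(C)c3oc2=O)ccc1O` follows from compound 2 by a group of 7 heavy atoms (7 carbon; 2 five-membered non-aromatic rings of carbon only) in place of a group of 2 heavy atoms (2 carbon; no ring), on an amine nitrogen. The step bearing most directly on this is a 1.1-fold lower number from compound 2 to compound 3 (0.04 log units; within the scatter), a change on the same amine nitrogen without movement beyond the scatter, so no shift beyond the scatter is expected for a 1.1-fold lower number from compound 2 to compound 4 (0.04 log units; within the scatter). Compound 4 is therefore expected at 650 nM, within 300 nM to 1400 nM.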

Compound 4, half-maximal inhibitory concentration: 770 nM
Compound 4: the middle estimate sits 1.2-fold (0.07 log units) below what was measured, and the stated range covers the measured number.
By their numbers in this assay, from the lowest: compounds 1, 3, 2 and 4 (each within the scatter of the next).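

In this assay the bridged two-ring group on the amine nitrogen of compound 4 causes no movement beyond the scatter (a 1.1-fold higher number from compound 2 to compound 4 (0.03 log units; within the scatter); a 1.2-fold higher number from compound 3 to compound 4 (0.07 log units; within the scatter)). The amine nitrogen therefore accepts 7 heavy atoms in two rings and 3 defined stereocentres, a wider change than ethyl to tert-butyl, with the number still within the scatter. The larger exchange also stays within the scatter (a 1.3-fold higher number from compound 1 to compound 4 (0.11 log units; within the scatter)). No measurement in hand accounts for this flat response. Open, as far as these compounds go, is whether a phenyl group or a carboxylic acid on that amine nitrogen would move the number beyond the scatter.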